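The source may hold more compounds than are shown below. What is called first, only, known or untested is meant among the compounds shown, and "the series" means these compounds.

Measured compounds:
- compound 1, `CCCCCOc1c(-c2cc(OC)c(OC)c(OC)c2)oc2ccccc2c1=O`: 22200 nM
- compound 2, `CCCCN(CCCC)CCCCOc1c(-c2cc(OC)c(OC)c(OC)c2)oc2ccccc2c1=O`: 5300 nM

In a functional assay on PC-3 cells (Homo sapiens) for antiproliferative activity, read by WST assay, with a stated time of 3 days (a lower number here means a stronger inhibitor, a higher number a weaker inhibitor), compound 1 gives the highest of the two numbers shown, so it is the weaker of the two measured inhibitors; the nearest number belongs to compound 2, which differs from it by dibutylamino in place of methyl on a saturated chain carbon, four bonds along the chain from an oxygen on an aromatic ring, and this step was a 4.2-fold lower number from compound 1 to compound 2 (0.62 log units; beyond the scatter).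

Compound 3, `CCCCCN(CCCCC)CCCOc1c(-c2cc(OC)c(OC)c(OC)c2)oc2ccccc2c1=O`, is not yet measured. Against compound 1 the change is dipentylamino in place of ethyl on a saturated chain carbon, three bonds along the chain from an oxygen on an aromatic ring. Going by the values given here, the only measured step that bears on it is the one from compound 1 to compound 2, in which a dialkylamino group also replaced the end of the chain on the same oxygen; that change gave a modest drop in the number, beyond the scatter. The change toward compound 3 is of the same kind, so a drop of roughly similar size is expected in this assay, though the chain differs in length and so the match is loose.

For compound 3 the estimate is 5500 nM, with a range of 1800 nM to 17000 nM, meaning an expected step of a 4.0-fold lower number from compound 1 to compound 3 (0.61 log units; beyond the scatter).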

Compound 3, half-maximal inhibitory concentration: 5800 nM
For compound 3 the middle estimate is 1.1-fold (0.02 log units) below the measured one; the measured number falls inside the stated range.
By their numbers in this assay, from the lowest: compounds 2 and 3 (each within the scatter of the next); then compound 1.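

In this assay, the step to dipentylamino gave a 3.8-fold lower number from compound 1 to compound 3 (0.58 log units; beyond the scatter), so the drop in the number seen with dibutylamino in compound 2 is not tied to that one amine: it also appears with longer groups on the nitrogen and with the nitrogen placed on a shorter chain. The two amine compounds are also close to each other, with a 1.1-fold higher number from compound 2 to compound 3 (0.04 log units; within the scatter), which means that dipentylamino on a saturated chain carbon, three bonds along the chain from an oxygen on an aromatic ring, gives a number that cannot be told apart from that of the dibutylamino compound, although this comparison alters both the chain and the groups on the nitrogen, so the two changes cannot be separated. No measurement shown here explains why adding these amines lowers the number.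

Still open, on these data alone, is whether a smaller amine such as dimethylamino, or a ring amine such as piperidine or morpholine, would lower the number further or lose the effect on the same chain. As far as these compounds go, it also remains unknown how dibutylamino would behave on the shorter chain of compound 3, or dipentylamino on the longer chain of compound 2, and those two compounds would show the effect of each change on its own.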